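Methyl replaces bromo in the 4-bromobenzyl compound

The source may report more compounds than this note shows. Statements on the series, on what has been measured and on what is new or still open speak of the compounds shown alone.

In a functional assay on KYSE-450 cells (Homo sapiens) for inhibition, read by CCK-8 assay, with a stated time of 48 h (on this read-out higher numbers stand for weaker inhibition and lower numbers for stronger inhibition), compound 1 (`COc1ccc(CN(C(=O)CSC(=S)N2CCN(C(=O)OC(C)(C)C)CC2)c2cc(OC)c(OC)c(OC)c2)cc1`) gives 250 nM and compound 2 (`COc1cc(N(Cc2ccc(Br)cc2)C(=O)CSC(=S)N2CCN(C(=O)OC(C)(C)C)CC2)cc(OC)c1OC`) gives 10700 nM, the higher of the two numbers. Compound 3 (`COc1cc(N(Cc2ccc(C)cc2)C(=O)CSC(=S)N2CCN(C(=O)OC(C)(C)C)CC2)cc(OC)c1OC`) carries methyl in place of bromo on an aromatic carbon. Going by the values given here, the only measured step at this place is large (a 43-fold higher number from compound 1 to compound 2 (1.63 log units; beyond the scatter)) and puts bromo in place of methoxy. Methyl has no measurement there, so this single step is the only guide. A partial return towards compound 1 is expected, less than that whole gap (a 7.1-fold lower number from compound 2 to compound 3 (0.85 log units; beyond the scatter)). Compound 3 is estimated at 1500 nM (300 nM to 8000 nM).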

Compound 3, half-maximal inhibitory concentration: > 20000 nM
Compound 3 gave a limit, no number; the forecaster's own chance of this, stated with the estimate: 3%; at least 13-fold (1.12 log units) between middle value and limit.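

In this assay compound 3 gives only a limit, not a number: the limit of > 20000 nM in this assay, at which 1 of the 3 values shown sits.

Methyl therefore brings no return towards compound 1, and the step reads an at least 1.8-fold higher number from compound 2 to compound 3 (0.27 log units; that floor lies within the scatter), so bromo and methyl are not separated. Of the three groups, methoxy alone stands apart, with an at least 80-fold higher number from compound 1 to compound 3 (1.90 log units; beyond the scatter).

On these data alone, it stays open whether ethoxy, hydroxy or a dimethylamino group on this aromatic carbon would keep the activity seen with methoxy or lose it as bromo and methyl do. As far as these compounds go, how far compound 3 really lies beyond its limit also remains unknown.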